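The source may report more compounds than this note shows. Statements on the series, on what has been measured and on what is new or still open speak of the compounds shown alone.

Of the compounds shown here, three that share one core have been measured in a functional assay on T47D cells (Homo sapiens) for inhibition, read by CCK-8 assay, with a stated time of 72 h, tested at 10 uM; a lower number here means less inhibition of growth, a higher number more inhibition of growth at the concentration tested. Compound 1 `CN(C)C(=O)c1cc2cnc(Nc3ccc(NC(=O)C4(C(=O)Nc5ccc(Cl)c(C(F)(F)F)c5)CC4)cc3)nc2n1C1CCCC1` gives 55.8% in this assay. Compound 2 `CN(C)C(=O)c1cc2cnc(Nc3ccc(NC(=O)C4(C(=O)Nc5cccc(C(F)(F)F)c5)CC4)cc3)nc2n1C1CCCC1` gives 92.7%, and compound 3 `CN(C)C(=O)c1cc2cnc(Nc3ccc(NC(=O)C4(C(=O)Nc5cccc(Cl)c5)CC4)cc3)nc2n1C1CCCC1` gives 92.6%. Compound 3 stands second highest of the three: the nearest step is a number 0.1 percentage points lower from compound 2 to compound 3 (within the scatter), within the scatter, while compound 1 lies far below, a number 36.8 percentage points higher from compound 1 to compound 3 (beyond the scatter). The remaining measured step, a number 36.9 percentage points higher from compound 1 to compound 2 (beyond the scatter), is of the same large size.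

Compound 4 `CN(C)C(=O)c1cc2cnc(Nc3ccc(NC(=O)C4(C(=O)Nc5ccc(O)cc5)CC4)cc3)nc2n1C1CCCC1` has not yet been measured in this assay. It differs from compound 3 in one place: 4-hydroxyphenyl in place of 3-chlorophenyl on an amide-type nitrogen. The step that bears on it most directly, a number 0.1 percentage points lower from compound 2 to compound 3 (within the scatter), put chloro in place of trifluoromethyl on an aromatic carbon and stayed within the scatter, whereas a number 36.9 percentage points higher from compound 1 to compound 2 (beyond the scatter) and a number 36.8 percentage points higher from compound 1 to compound 3 (beyond the scatter) show that the group on this amide-type nitrogen can move the number a long way. Among the measured compounds shown here, no measured step brings in a 4-hydroxyphenyl, so the expectation rests on compound 3 with a wide margin. The step is expected to be a number 17.6 percentage points lower from compound 3 to compound 4 (beyond the scatter). Compound 4 is therefore estimated at 75% in this assay, with a range from 45% to 95%.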

Compound 4, percent growth inhibition at one concentration: 95.8%
Compound 4: middle estimate off by 20.8 percentage points, on the low side; the measured number lies above the stated range.
By their numbers in this assay, from the lowest: compound 1; then compounds 3, 2 and 4 (each within the scatter of the next).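

On the amide-type nitrogen, 4-hydroxyphenyl replaces 3-chlorophenyl with a number 3.2 percentage points higher from compound 3 to compound 4 (within the scatter) in this assay and replaces 3-(trifluoromethyl)phenyl with a number 3.1 percentage points higher from compound 2 to compound 4 (within the scatter), so this position accepts a ring with a hydrogen-bond donor and acceptor, which 3-chlorophenyl lacks, with no change beyond the scatter. Against 4-chloro-3-(trifluoromethyl)phenyl, the same group gives a number 40 percentage points higher from compound 1 to compound 4 (beyond the scatter), which leaves compound 1 as the only one of the four set apart, and compound 4 shows that a group at the 4 position of this ring does not by itself bring the low number. Nothing shown here explains why these groups read alike or why compound 1 differs.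

On these data alone, how 4-chlorophenyl alone would read at this position remains open. So does whether a ring carrying an amine or a carboxylic acid, or a longer chain in place of the ring, would keep the number at this level.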